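Replacing 2-fluorophenyl in compound 3 with 4-nitrophenyl

This account rests on a few compounds, and the source may have more. Where it says the series, first, only, none or still open, it means among the compounds named here.

Within the data shown here, in a functional assay on MCF7 cells (Homo sapiens) for cytotoxicity, read by MTT assay, with a stated time of 96 h (a lower number here means a stronger inhibitor, a higher number a weaker inhibitor), compound 3 (`COc1cc(C(=O)c2cn(-c3cccc(N)c3)cc2-c2ccccc2F)cc(OC)c1OC`) gives 17 nM, the lowest of the three numbers so far. Compound 2 (`COc1cc(C(=O)c2cn(-c3cccc(C)c3)cc2-c2ccccc2F)cc(OC)c1OC`) gives 190 nM, and compound 1 (`COc1cc(C(=O)c2cn(-c3ccccc3N)cc2-c2ccccc2)cc(OC)c1OC`) gives 3800 nM. Among the measured compounds shown here, the only measured step, an 11-fold lower number from compound 2 to compound 3 (1.05 log units; beyond the scatter), is large and beyond the scatter, and it goes with amino in place of methyl on an aromatic carbon.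

Compound 4 (`COc1cc(C(=O)c2cn(-c3cccc(N)c3)cc2-c2ccc([N+](=O)[O-])cc2)cc(OC)c1OC`) keeps the 3-aminophenyl group of compound 3 and carries 4-nitrophenyl in place of 2-fluorophenyl on an aromatic carbon. For the measured compounds named here, no measured step covers this exchange, and compound 1 differs from compound 3 in more than one place, so the size of the step rests on little. The retained amino favours a low number, as the value of 17 nM for compound 3 shows. A modest rise is expected, possibly not beyond the scatter: a 2.4-fold higher number from compound 3 to compound 4 (0.37 log units; beyond the scatter). For compound 4 the estimated value is 40 nM, with an expected range from 8 nM to 200 nM.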

Compound 4, half-maximal inhibitory concentration: 110 nM
For compound 4 the middle estimate is 2.8-fold (0.44 log units) below the measured one; the measured number falls inside the stated range.
By their numbers in this assay, from the lowest: compound 3; then compounds 4 and 2 (each within the scatter of the next); then compound 1.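

In this assay the carbon of the five-membered aromatic ring two ring bonds from the ring nitrogen now has its first measured exchange, with the 3-aminophenyl group held constant: a 6.5-fold higher number from compound 3 to compound 4 (0.81 log units; beyond the scatter) goes with 4-nitrophenyl in place of 2-fluorophenyl. The number therefore depends on the aryl group at this position as well as on the amino group, yet compound 4 still gives 110 nM with the larger 4-nitrophenyl group in place. Nothing measured on either group accounts for this step.

The exchange alters both the substituent and its place on the phenyl ring, so 4-fluorophenyl or 2-nitrophenyl at this carbon would be needed to separate the two. As far as these compounds go, whether the step carries over to a 3-methylphenyl partner also stays open.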